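This account rests on a few compounds, and the source may have more. Where it says the series, first, only, none or still open, it means among the compounds named here.

Compound 3 `COc1ccc(CCC(C)(C)C)c(N2CCC(COc3cccc(C(CC(=O)O)C4CC4)c3)CC2)c1` carries the shared core with a 3,3-dimethylbutyl group on an aromatic carbon. In a functional assay on cells for agonist activity at Free fatty acid receptor 1 (Homo sapiens), read by FLIPR and calcium flux, with a stated time of 60 min (on this read-out higher numbers stand for an effect only at larger amounts of compound and lower numbers for an effect already at smaller amounts), compound 3 gives 34 nM, the second highest of the three numbers shown. Compound 1 `COc1ccc(CCCC(C)(C)C)c(N2CCC(COc3cccc(C(CC(=O)O)C4CC4)c3)CC2)c1` gives 11 nM and compound 2 `COc1ccc(C(C)C)c(N2CCC(COc3cccc(C(CC(=O)O)C4CC4)c3)CC2)c1` gives 120 nM; the steps of a 3.1-fold higher number from compound 1 to compound 3 (0.49 log units; beyond the scatter) and a 3.5-fold lower number from compound 2 to compound 3 (0.55 log units; beyond the scatter) are both modest, while an 11-fold higher number from compound 1 to compound 2 (1.04 log units; beyond the scatter) is large. Compound 4 `COc1ccc(CCC(C)(C)O)c(N2CCC(COc3cccc(C(CC(=O)O)C4CC4)c3)CC2)c1` differs from compound 3 by hydroxy in place of methyl on a saturated chain carbon bound to three saturated chain carbons. Among the compounds with values here, none of the measured steps exchanges a carbon for an oxygen in this chain, so they bear only loosely on it. A modest rise in the number is expected, a 2.4-fold higher number from compound 3 to compound 4 (0.37 log units; beyond the scatter), giving compound 4 an estimated 80 nM within 25 nM to 300 nM.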

Compound 4, half-maximal effective concentration: 970 nM
Compound 4: the middle estimate sits 12-fold (1.08 log units) below what was measured; the whole stated range lies below it.
By their numbers in this assay, from the lowest: compound 1; then compound 3; then compound 2; then compound 4.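

In this assay, hydroxy in place of methyl on this saturated chain carbon gives a 29-fold higher number from compound 3 to compound 4 (1.46 log units; beyond the scatter), a larger step than any among the first three compounds. The change in one heavy atom also outweighs chain length here: 3-hydroxy-3-methylbutyl in place of isopropyl gives an 8.1-fold higher number from compound 2 to compound 4 (0.91 log units; beyond the scatter), and the gap to the longest chain is an 88-fold higher number from compound 1 to compound 4 (1.95 log units; beyond the scatter). Nothing available explains the size of this step.

Going by these compounds, whether an amine or a methoxy group on the same carbon would give a similar step remains open, as does the effect of hydroxy on a longer chain.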